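Working notes: benzyl substituent steps, one series

The compounds below may be only part of what the source reports. "The series", "measured", "known", "first", "only" and "open" are said of these compounds alone.

Compound 1 `Cc1ccc(NC(=S)NC(=O)c2ccc(OCc3ccccc3)cc2)cc1-c1nc2ccccc2[nH]1` — 60700 nM in a functional assay on MGC-803 cells (Homo sapiens) for inhibition, read by MTT assay, with a stated time of 48 h; on this read-out lower numbers stand for stronger inhibition and higher numbers for weaker inhibition
Compound 2 `Cc1ccc(COc2ccc(C(=O)NC(=S)Nc3ccc(C)c(-c4nc5ccccc5[nH]4)c3)cc2)cc1` — 4980 nM in this assay

Compound 2 gives the lowest of the two numbers in this assay; compound 1 sits a step above it. Compound 3 `Cc1ccc(NC(=S)NC(=O)c2ccc(OCc3ccc(Cl)cc3Cl)cc2)cc1-c1nc2ccccc2[nH]1` is not yet measured; it differs from compound 2 by 2,4-dichlorophenyl in place of 4-methylphenyl on a saturated chain carbon bound to an oxygen on an aromatic ring. Going by the values given here, the only measured step, a 12-fold lower number from compound 1 to compound 2 (1.09 log units; beyond the scatter), shows that changing the substituent on this benzyl group can move the number by a large amount, but no measured step tells about chlorine here. Compound 3 is therefore expected near 8000 nM, with a range of 2000 nM to 30000 nM. The expected step is a 1.6-fold higher number from compound 2 to compound 3 (0.21 log units; within the scatter), within the scatter.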

Compound 3, half-maximal inhibitory concentration: 3450 nM
The estimate for compound 3 lay 2.3-fold (0.37 log units) above the measured number; low and high end bracket the measured number.
By their numbers in this assay, from the lowest: compounds 3 and 2 (each within the scatter of the next); then compound 1.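

The step to 2,4-dichlorophenyl is a 1.4-fold lower number from compound 2 to compound 3 (0.16 log units; within the scatter) in this assay and so does not separate it from 4-methylphenyl on this saturated chain carbon. Measured against the unsubstituted phenyl, the same group gives an 18-fold lower number from compound 1 to compound 3 (1.25 log units; beyond the scatter) and thus joins 4-methylphenyl in standing clear of compound 1. No evidence is available that bears on the size of these steps.

Still open, on these data alone, is whether one chlorine alone would give a comparable number. As far as these compounds go, the effect of an amine or a carboxylic acid on this ring, or of a longer chain in place of the benzyl group, also remains unknown.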